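The source may hold more compounds than are shown below. What is called first, only, known or untested is meant among the compounds shown, and "the series" means these compounds.

Within the data shown here, compound 1 `C1CCC(c2nnc3nnc(N4CCCC4)nn23)CC1` holds the only numerical value so far: in a functional assay on MCF7 cells (Homo sapiens) for cytotoxicity, read by MTT assay, with a stated time of 72 h (on this read-out higher numbers stand for weaker inhibition and lower numbers for stronger inhibition), compound 1 gives 37700 nM. Compound 2 `O=[N+]([O-])c1ccc(-c2nnc3nnc(N4CCCC4)n3n2)cc1` reaches only a limit in this assay, namely > 100000 nM, which is the limit of > 100000 nM in this assay, at which 1 of the 2 values shown sits. Compound 3 `CCc1nnc2nnc(N3CCCC3)nn12` differs from compound 1 by ethyl in place of cyclohexyl on an aromatic carbon. Among the measured compounds shown here, no measured pair shows a change of this kind, so the size of its step is unknown. With the cyclohexyl gone, the step from compound 1 to compound 3 is expected to be modest and toward weaker inhibition, a 1.9-fold higher number from compound 1 to compound 3 (0.27 log units; within the scatter). Compound 3 is therefore estimated at 70000 nM, within 25000 nM to 150000 nM.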

Compound 3, half-maximal inhibitory concentration: 47000 nM
Beside the measured number, compound 3's estimate is 1.5-fold (0.17 log units) above it, within the range that was stated.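

In this assay, among these compounds, the exchange of cyclohexyl for ethyl on an aromatic carbon of the five-membered aromatic ring gives a 1.2-fold higher number from compound 1 to compound 3 (0.10 log units; within the scatter) and is the first change at this position that can be read. The six-membered carbon ring can therefore go without the number leaving the scatter of compound 1. No measurement shown gives a reason for this step. The compounds shown leave open whether an amine, a carboxylic acid or a longer chain such as hexyl at this position would move the number beyond the scatter.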